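Fluoro to (3-fluorobenzyl)oxy on compound 3

The source may hold more compounds than are shown below. What is called first, only, known or untested is meant among the compounds shown, and "the series" means these compounds.

compound 1 `C=CC(=O)Nc1cc2c(Nc3ccc(OCc4cccc(F)c4)c(Cl)c3)ncnc2cc1OCc1cn(CCCC(=O)NO)nn1`: 20200 nM 
compound 2 `C=CC(=O)Nc1cc2c(Nc3ccc(OCc4cccc(F)c4)c(Cl)c3)ncnc2cc1OCc1cn(CCCCC(=O)NO)nn1`: 16000 nM 
compound 3 `C=CC(=O)Nc1cc2c(Nc3ccc(F)c(Cl)c3)ncnc2cc1OCc1cn(CCC(=O)NO)nn1`: > 50000 nM (a limit, not a number)

All three results come from a functional assay on SK-BR-3 cells (Homo sapiens) for antiproliferative activity, read by MTT assay, with a stated time of 72 h (a lower number here means a stronger inhibitor, a higher number a weaker inhibitor), and are given as the half-maximal inhibitory concentration. Compound 3 has no number in this assay and is recorded only as a limit (> 50000 nM). Compound 4 (`C=CC(=O)Nc1cc2c(Nc3ccc(OCc4cccc(F)c4)c(Cl)c3)ncnc2cc1OCc1cn(CCC(=O)NO)nn1`) has (3-fluorobenzyl)oxy in place of fluoro on an aromatic carbon, ortho to a chloro group and para to a large group ((3-fluorobenzyl)oxy in place of fluoro on an aromatic carbon).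

Among the measured compounds shown here, no measured step covers this exchange directly. The nearest evidence comes from compound 1 (20200 nM) and compound 2 (16000 nM), which both carry the (3-fluorobenzyl)oxy group. For the measured compounds named here, the one measured step, a change in the chain bearing the hydroxycarbamoyl group, stays within the scatter (a 1.3-fold lower number from compound 1 to compound 2 (0.10 log units; within the scatter)). Compound 4 carries the same group but differs from both in that chain, so its value is expected near theirs, with some added uncertainty. The expected change is toward a lower number (an at least 2.2-fold lower number from compound 3 to compound 4 (0.35 log units; beyond the scatter)) but its size is only approximate, as it starts from a limit. Compound 4 is estimated at 22000 nM in this assay (expected range 9000 nM to 50000 nM).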

Compound 4, half-maximal inhibitory concentration: 24800 nM
Estimate against measurement, compound 4: 1.1-fold (0.05 log units) below; the measured number falls inside the stated range.
By their numbers in this assay, from the lowest: compounds 2, 1 and 4 (each within the scatter of the next). At a limit, above all of these: compound 3.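

Compound 3 is recorded in this assay only as a limit, not as a number: the limit of > 50000 nM in this assay, at which 1 of the 4 values shown sits.

As far as these compounds go, putting (3-fluorobenzyl)oxy in place of fluoro, on the aromatic carbon ortho to a chloro group, brings the series to a measured number, with an at least 2.0-fold lower number from compound 3 to compound 4 (0.30 log units; that floor lies within the scatter); this is only a floor, so the true size of the change stays unknown, and the data cannot show that the exchange moves the number beyond the scatter. With (3-fluorobenzyl)oxy held in place, the new compound also extends the comparison of the chain bearing the hydroxycarbamoyl group, with a 1.6-fold higher number from compound 2 to compound 4 (0.19 log units; within the scatter) and a 1.2-fold higher number from compound 1 to compound 4 (0.09 log units; within the scatter), so these chain changes, like the earlier single step, give no order among the three compounds.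

What the compounds shown leave open is how far the number would move with a smaller ether such as methoxy, or with a benzyloxy group lacking its fluorine, on the same aromatic carbon. From the compounds shown here alone, it is also open whether a chain longer than those in compound 1, compound 2 and compound 4, or a carboxylic acid in place of the hydroxycarbamoyl group, would change the number in this assay.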